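A few compounds are considered here, and "the series" means these few. Any claim that something is new, unique, unknown or untested is made for them only; others in the source may bear on it.

In a functional assay on Hep 3B2 cells (Homo sapiens) for antiproliferative activity, read by MTT assay, with a stated time of 72 h (on this read-out higher numbers stand for weaker inhibition and lower numbers for stronger inhibition), compound 2 (`COC(=O)c1ccc(-n2cc(CCCOS(=O)(=O)c3cccc(OC)c3)nn2)cc1`) gives 20900 nM and compound 1 (`COC(=O)c1ccc(-n2cc(CCCOS(=O)(=O)c3ccc(-c4ccccc4)cc3)nn2)cc1`) gives 26000 nM in the same test, so these two sit within the scatter of each other. Compound 3 (`COC(=O)c1ccc(-n2cc(CCCOS(=O)(=O)c3cccc(F)c3)nn2)cc1`) gives > 50000 nM which is a limit of the assay and not a number. Compound 4 (`COC(=O)c1ccc(-n2cc(CCCOS(=O)(=O)c3ccccc3C)nn2)cc1`) differs from compound 2 by 2-methylphenyl in place of 3-methoxyphenyl on a sulfonyl sulfur. For the measured compounds named here, only one measured step bears on this change. It is an at least 2.3-fold higher number from compound 2 to compound 3 (0.37 log units; beyond the scatter) with fluoro in place of methoxy on an aromatic carbon, and its size is known only as a bound. Going by the values given here, compound 1 is joined to no other compound by a single change and so supplies no step. Compound 4 gives up the methoxy as compound 3 does, so on the strength of that single step (an at least 2.3-fold higher number from compound 2 to compound 3 (0.37 log units; beyond the scatter)) a small move towards a higher number is expected in this assay with a real chance that only a limit is reported. The expected step is a 1.5-fold higher number from compound 2 to compound 4 (0.19 log units; within the scatter) and it may not clear the scatter. For compound 4 the estimated value is 32000 nM with 13000 nM to 60000 nM as the expected range.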

Compound 4, half-maximal inhibitory concentration: > 50000 nM
Compound 4 gave a limit, no number; the forecaster's own chance of this, stated with the estimate: 35%; middle value at least 1.5-fold (0.19 log units) from the limit.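

In this assay, 2-methylphenyl in place of 3-methoxyphenyl on a sulfonyl sulfur gives an at least 2.3-fold higher number from compound 2 to compound 4 (0.37 log units; beyond the scatter), so a second replacement of the 3-methoxyphenyl group, after the fluoro change in compound 3, also weakens inhibition beyond the scatter. Compound 4 gives > 50000 nM, which is a limit of the assay and not a number, so this step is known only as a bound. The step between compound 3 and compound 4 cannot be read, and the two can't be ranked, because both rest on the same limit: the limit of > 50000 nM in this assay, at which 2 of the 4 values shown sit.

On these data alone, whether the methoxy group itself is what matters stays open, since compound 1 carries no methoxy and still gives 26000 nM, a value that goes against any rule tying a measurable number to that group. As far as these compounds go, it is also open whether an amine or a carboxylic acid on the phenyl ring in place of the methoxy, or a longer chain in place of the one in the shared core, would give a number in this assay rather than a limit.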